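Volume of Distribution in Dog: From Compound 1 to Compound 3

This account rests on a few compounds, and the source may have more. Where it says the series, first, only, none or still open, it means among the compounds named here.

Measured compounds:
compound 1 `CCn1c(-c2cnc(C)nc2)nc2c(O[C@H]3CCN(C(=O)C4CCC4)C3)ncnc21`: 1 L/kg
compound 2 `CCn1c(-c2cnc(C)nc2)nc2c(N[C@H]3CCN(C(=O)C4CC4)C3)ncnc21`: 1.5 L/kg

In an ADME assay (Canis lupus familiaris, strain Beagle) for pharmacokinetics (on this read-out lower numbers stand for narrower distribution and higher numbers for wider distribution into tissues), compound 1 holds the lowest of the two numbers, and compound 2 sits within the scatter of it, so the two show no real separation. Compound 3 `CCn1c(-c2cnc(C)nc2)nc2c(O[C@H]3CCN(C(=O)N4CC(OC)C4)C3)ncnc21` differs from compound 1 by 3-methoxyazetidin-1-yl in place of cyclobutyl on a carbonyl carbon. Going by the values given here, no step between measured compounds is available to guide the size of this change, so only a step within the scatter is expected, if anything slightly toward a narrower distribution, a 1.1-fold lower number from compound 1 to compound 3 (0.05 log units; within the scatter). Compound 3 is therefore estimated at 0.9 L/kg, within 0.5 L/kg to 1.6 L/kg.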

Compound 3, volume of distribution: 1.4 L/kg
Estimate against measurement, compound 3: 1.6-fold (0.19 log units) below, and the stated range covers the measured number.
By their numbers in this assay, from the lowest: compounds 1, 3 and 2 (each within the scatter of the next).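

In this assay, going by these compounds alone, the replacement of cyclobutyl by 3-methoxyazetidin-1-yl on a carbonyl carbon gives the first step that can be read at this position: a 1.4-fold higher number from compound 1 to compound 3 (0.15 log units; within the scatter). The position thus accepts a larger group carrying one hydrogen-bond acceptor without a separation beyond the scatter. Nothing shown explains this result.

As far as these compounds go, whether a basic amine or a carboxylic acid on this carbonyl carbon would move the read-out beyond the scatter remains open. The same holds for a longer chain in place of the four-membered ring.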